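This account rests on a few compounds, and the source may have more. Where it says the series, first, only, none or still open, it means among the compounds named here.

Of the compounds shown here, three sharing one core have been measured in an assay on isolated protein for inhibition of Equilibrative nucleoside transporter 1 (Homo sapiens); on this read-out lower numbers stand for stronger inhibition and higher numbers for weaker inhibition. Compound 2 `OC[C@H]1O[C@@H](n2cnc3c(SCc4ccc(Br)cc4)ncnc32)[C@H](O)[C@@H]1O` gives 11.5 nM. Compound 3 `OC[C@H]1O[C@@H](n2cnc3c(SCc4ccccc4I)ncnc32)[C@H](O)[C@@H]1O` gives 19.5 nM, and compound 1 `OC[C@H]1O[C@@H](n2cnc3c(SCc4ccccc4Br)ncnc32)[C@H](O)[C@@H]1O` gives 151 nM. Compound 2 therefore holds the lowest of the three numbers; the step of a 1.7-fold higher number from compound 2 to compound 3 (0.23 log units; within the scatter) stays within the scatter, whereas a 13-fold lower number from compound 1 to compound 2 (1.12 log units; beyond the scatter) lies beyond it, so compound 2 and compound 3 cannot be separated from each other, but both stand clearly apart from compound 1.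

The change from compound 2 to compound 4 `N#Cc1ccc(CSc2ncnc3c2ncn3[C@@H]2O[C@H](CO)[C@@H](O)[C@H]2O)cc1` is cyano in place of bromo on an aromatic carbon. Among the compounds with values here, no measured step swaps bromo for cyano. Within the data shown here, the nearest precedent is the halogen exchange a 7.7-fold lower number from compound 1 to compound 3 (0.89 log units; beyond the scatter), also on an aromatic carbon, and the only other step, a 13-fold lower number from compound 1 to compound 2 (1.12 log units; beyond the scatter), moves the group rather than replacing it. On this basis a small step is expected in this assay this assay, in either direction and probably within the scatter, with a wide range to reflect the missing precedent. Compound 4 is estimated at 25 nM, within 8 nM to 80 nM. The expected step is then a 2.2-fold higher number from compound 2 to compound 4 (0.34 log units; beyond the scatter).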

Compound 4, inhibition constant: 4.57 nM
Estimate against measurement, compound 4: 5.5-fold (0.74 log units) above; measured number outside the range, below it.
By their numbers in this assay, from the lowest: compound 4; then compounds 2 and 3 (each within the scatter of the next); then compound 1.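

Working from this assay, the aromatic carbon para to a large group tolerates more than a halogen: cyano in place of bromo gives a 2.5-fold lower number from compound 2 to compound 4 (0.40 log units; beyond the scatter), the first true replacement at this position rather than a move of the group. Compound 2 could not be separated from compound 3, but the cyano compound can, with a 4.3-fold lower number from compound 3 to compound 4 (0.63 log units; beyond the scatter), and a 33-fold lower number from compound 1 to compound 4 (1.52 log units; beyond the scatter) is the widest step in the series, so compound 4 now stands apart from all three others. Nothing available accounts for the gain of cyano over bromo.

On these data alone, with only bromo and cyano at this position, how a carboxylic acid, an amine or a methoxy group would read there remains open. Also open, as far as these compounds go, is whether 2-cyanophenyl would match 4-cyanophenyl.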